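This account rests on a few compounds, and the source may have more. Where it says the series, first, only, none or still open, it means among the compounds named here.

Compound 1 `CC(C)=CCC[C@]1(C)/C=C/[C@@H](OC(=O)C=C(C)C)[C@](C)(O)/C=C/C(=O)/C(CN(C)C)=C\C1`: 140 nM
Compound 2 `CCN(CC)C(=O)/C1=C/C[C@](C)(CCC=C(C)C)/C=C/[C@@H](OC(=O)C=C(C)C)[C@](C)(O)/C=C/C1=O`: 9080 nM

In a functional assay on HL-60 cells (Homo sapiens) for antiproliferative activity, read by MTT assay, with a stated time of 48 h (a higher number here means a weaker inhibitor, a lower number a stronger inhibitor), compound 2 gives 9080 nM, the higher of the two numbers. Compound 3 `CC(C)=CCC[C@]1(C)/C=C/[C@@H](OC(=O)C=C(C)C)[C@](C)(O)/C=C/C(=O)/C(C(=O)N(C(C)C)C(C)C)=C\C1` differs from it by diisopropylamino in place of diethylamino on a carbonyl carbon. Among the compounds with values here, the only measured step, a 65-fold higher number from compound 1 to compound 2 (1.81 log units; beyond the scatter), is large, but it exchanges (dimethylamino)methyl for diethylcarbamoyl, a different change. Within the data shown here, no measured step swaps one amino group on the carbonyl for another, so no large shift is expected and no direction is favoured. The step expected in this assay is a 1.0-fold lower number from compound 2 to compound 3 (0.00 log units; within the scatter). Compound 3 is expected at 9000 nM, with an estimated range of 3500 nM to 25000 nM.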

Compound 3, half-maximal inhibitory concentration: 12700 nM
For compound 3 the middle estimate is 1.4-fold (0.15 log units) below the measured one; measured number inside the range.
By their numbers in this assay, from the lowest: compound 1; then compounds 2 and 3 (each within the scatter of the next).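

In this assay, diisopropylamino in place of diethylamino on the carbonyl carbon gives a 1.4-fold higher number from compound 2 to compound 3 (0.15 log units; within the scatter) and so stays within the scatter; this exchange on the amide does not separate the two compounds. The large gap to the (dimethylamino)methyl compound now holds for a second carbamoyl group, at a 91-fold higher number from compound 1 to compound 3 (1.96 log units; beyond the scatter) and beyond the scatter. No measured evidence accounts for these numbers. The compounds shown leave open how a (diethylamino)methyl group on the double-bonded ring carbon would compare, and whether an amide carrying a piperidine ring would stay with compound 2 and compound 3.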